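Pyridin-2-yl Amide in Place of the Methylphenyl Parent

The compounds below may be only part of what the source reports. "The series", "measured", "known", "first", "only" and "open" are said of these compounds alone.

compound 1 `COc1cc2c(cc1OC)C(CC(=O)Nc1cccc(Cl)c1)CC2` — 25.8%
compound 2 `COc1cc2c(cc1OC)C(CC(=O)Nc1cccc(C)c1)CC2` — 40.6%

Compound 1 `COc1cc2c(cc1OC)C(CC(=O)Nc1cccc(Cl)c1)CC2` and compound 2 `COc1cc2c(cc1OC)C(CC(=O)Nc1cccc(C)c1)CC2` share a core and differ only in one substituent on an aromatic carbon. In a functional assay on the whole organism (strain Wistar) for inhibition, with Rattus norvegicus as the target, read by paw edema, with a stated time of 4 h, at a dose of 100 mg/kg (a lower number here means less inhibition, a higher number more inhibition at the dose given (going by the name of the read-out)), compound 1 gives 25.8%, and compound 2 gives 40.6%. Compound 2 thus stands highest of the two numbers, with compound 1 as its nearest neighbour, the step being a number 14.8 percentage points higher from compound 1 to compound 2 (beyond the scatter).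

Compound 3 `COc1cc2c(cc1OC)C(CC(=O)Nc1ccccn1)CC2` continues from compound 2: pyridin-2-yl in place of 3-methylphenyl on an amide-type nitrogen. Within the data shown here, no measured step bears directly on this change; the only step at hand, a number 14.8 percentage points higher from compound 1 to compound 2 (beyond the scatter), swaps one substituent on the aromatic ring for another and keeps the ring itself, showing only that a modest change there can move the read-out beyond the scatter. Exchanging the whole 3-methylphenyl for pyridin-2-yl is a larger change whose direction the two values do not fix. The account therefore expects a step of a number 8.6 percentage points lower from compound 2 to compound 3 (within the scatter), most likely a modest decrease with wide uncertainty. Compound 3 is estimated at 32%, within 14% to 50%.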

Compound 3, a percentage reported as inhibition, in the whole organism at one dose (the size of the read-out at that dose, not a potency): 29.7%
The estimate for compound 3 lay 2.3 percentage points above the measured number; low and high end bracket the measured number.
By their numbers in this assay, from the lowest: compounds 1 and 3 (each within the scatter of the next); then compound 2.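

Earlier, only a substituent on the aromatic ring had changed; here the ring on the amide-type nitrogen itself is exchanged, and pyridin-2-yl for 3-methylphenyl gives a number 10.9 percentage points lower from compound 2 to compound 3 (beyond the scatter) in this assay at this position. Against the chlorinated parent, the exchange gives a number 3.9 percentage points higher from compound 1 to compound 3 (within the scatter) and so leaves pyridin-2-yl and 3-chlorophenyl indistinguishable here, with only 3-methylphenyl standing apart from the other two groups. No evidence is at hand to explain these differences.

As far as these compounds go, it remains open whether pyridin-3-yl or pyridin-4-yl on the same nitrogen would read like pyridin-2-yl, or whether the ring nitrogen matters at all once a methyl group is added to the pyridine ring. A saturated piperidine ring or a plain ethyl chain on this nitrogen is equally untested by the compounds shown here.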